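The compounds below may be only part of what the source reports. "The series", "measured", "known", "first", "only" and "open" are said of these compounds alone.

Measured so far:
Compound 1 `CC1=C(CC(=O)N(C)CCN(C)S(=O)(=O)c2ccccc2)c2cc(F)ccc2/C1=C\c1ccc([S+](C)[O-])cc1`: 12200 nM
Compound 2 `CC1=C(CC(=O)N(C)CCN(C)S(=O)(=O)c2ccc(C)cc2)c2cc(F)ccc2/C1=C\c1ccc([S+](C)[O-])cc1`: 17800 nM

Both compounds were tested in a functional assay on MDA-MB-231 cells (Homo sapiens) for inhibition, read by CellTiter-Glo, with a stated time of 72 h; on this read-out higher numbers stand for lower toxicity in this test and lower numbers for higher toxicity in this test. In this assay, for the measured compounds named here, compound 2 gives 17800 nM, the highest of the two numbers, but its only neighbour is compound 1 with 12200 nM, and the gap between them is within the scatter, so no order can be read from it.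

The step to compound 3 `CC1=C(CC(=O)N(C)CCN(C)S(=O)(=O)c2cccc3ccccc23)c2cc(F)ccc2/C1=C\c1ccc([S+](C)[O-])cc1` brings (naphthalen-1-yl in place of 4-methylphenyl on a sulfonyl sulfur). Going by the values given here, the only measured step, a 1.5-fold higher number from compound 1 to compound 2 (0.16 log units; within the scatter), touched the same aromatic ring through a smaller change and stayed within the scatter. Among the compounds with values here, no measured step shows what a second fused ring at this position does, so the expectation rests on that single small step: no move beyond the scatter in this assay is expected, and the estimated step of a 1.0-fold higher number from compound 2 to compound 3 (0.00 log units; within the scatter) reflects this.

Compound 3 is therefore expected to give about 18000 nM in this assay, within a range of 7000 nM to 45000 nM.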

Compound 3, half-maximal cytotoxic concentration: 29100 nM
Compound 3: middle estimate off by 1.6-fold (0.21 log units), on the low side, and the stated range covers the measured number.
By their numbers in this assay, from the lowest: compounds 1, 2 and 3 (each within the scatter of the next, the first and the last beyond it).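

In this assay, naphthalen-1-yl in place of 4-methylphenyl on the sulfonyl sulfur gives a step that cannot be told apart from repeat variation (a 1.6-fold higher number from compound 2 to compound 3 (0.21 log units; within the scatter)). For the compounds shown here, measured against the plain phenyl, the same group gives the first step at this position to pass the scatter (a 2.4-fold higher number from compound 1 to compound 3 (0.38 log units; beyond the scatter)), a modest move toward lower toxicity in this test. Nothing available explains why this step occurs.

The aromatic groups on the sulfonyl sulfur in these compounds are all built of carbon only, so a pyridine ring there, or a phenyl carrying an amine or a carboxylic acid, remains an open case. The compounds shown also leave open how a longer chain in place of the aromatic group would read in this assay.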